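Amide variation on the pyrazole series: toward compound 4

The compounds below may be only part of what the source reports. "The series", "measured", "known", "first", "only" and "open" are said of these compounds alone.

Measured so far:
Compound 1 `CC(C)c1c(C(=O)N(C)Cc2ccccc2)nn(-c2ccc(F)cc2)c1CC[C@@H](O)C[C@@H](O)CC(=O)O` — 6.2 nM
Compound 2 `CC(C)c1c(C(=O)N2CCC[C@H](c3ccccc3)C2)nn(-c2ccc(F)cc2)c1OC[C@@H](O)C[C@@H](O)CC(=O)O` — 4.8 nM
Compound 3 `CC(C)c1c(C(=O)N2CCCCC2)nn(-c2ccc(F)cc2)c1OC[C@@H](O)C[C@@H](O)CC(=O)O` — 47 nM

In an assay on microsomes from liver for inhibition of 3-hydroxy-3-methylglutaryl-coenzyme A reductase (Rattus norvegicus) (on this read-out lower numbers stand for stronger inhibition and higher numbers for weaker inhibition), compound 3 gives 47 nM, the highest of the three numbers; compound 1 gives 6.2 nM and compound 2 gives 4.8 nM, both beyond the scatter from compound 3. Compound 4 `Cc1cccc(CN(C)C(=O)c2nn(-c3ccc(F)cc3)c(OC[C@@H](O)C[C@@H](O)CC(=O)O)c2C(C)C)c1` is not yet measured. It differs from compound 3 in one place: methyl(3-methylbenzyl)amino in place of piperidin-1-yl on a carbonyl carbon.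

Among the compounds with values here, one measured step bears on this change. The step of a 9.8-fold higher number from compound 2 to compound 3 (0.99 log units; beyond the scatter) shows that removing an aromatic ring from the amide part raised the number well beyond the scatter. Compound 4 restores an aromatic ring to the amide part, so a step of comparable size in the opposite direction is expected. Within the data shown here, compound 1, which carries a methylbenzyl-type amide on a different linker, gives 6.2 nM; no single-point step joins it to compound 4, so it serves only as a pointer.

The expected step is a 6.7-fold lower number from compound 3 to compound 4 (0.83 log units; beyond the scatter). For compound 4 the estimate in this assay is 7 nM, with a range from 3 nM to 20 nM.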

Compound 4, half-maximal inhibitory concentration: 37 nM
For compound 4 the middle estimate is 5.3-fold (0.72 log units) below the measured one, and the stated range ends below it.
By their numbers in this assay, from the lowest: compounds 2 and 1 (each within the scatter of the next); then compounds 4 and 3 (each within the scatter of the next).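

In this assay, putting an aromatic ring back on the amide part does not by itself lower the number: a 1.3-fold lower number from compound 3 to compound 4 (0.10 log units; within the scatter) shows that methyl(3-methylbenzyl)amino and piperidin-1-yl on this carbonyl carbon cannot be told apart, despite the larger group entering. With the same group in place of 3-phenylpiperidin-1-yl, a 7.7-fold higher number from compound 2 to compound 4 (0.89 log units; beyond the scatter) places compound 2 alone among these three amides, so the step seen on removing the phenyl does not simply reverse when any aromatic ring is restored. Nothing available accounts for the difference between these two aromatic amides.

Going by these compounds, it remains open whether 4-phenylpiperidin-1-yl on this carbonyl carbon would fall with compound 2 or with compound 3. The same question stands for methyl(benzyl)amino, which lacks the ring methyl of compound 4, on the core of compound 4.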